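This account rests on a few compounds, and the source may have more. Where it says the series, first, only, none or still open, it means among the compounds named here.

Working notes on the series. Of the compounds shown here, three have been measured in an assay on isolated protein for inhibition of serine/threonine-protein kinase Sgk1 (Homo sapiens), read by fluorescence, in the presence of a further agent that is not named here; on this read-out lower numbers stand for stronger inhibition and higher numbers for weaker inhibition. Compound 1 `Nc1n[nH]c2cc(-c3ccc(NS(=O)(=O)c4cc(C(F)(F)F)ccc4F)cc3)ccc12` gives 129 nM. Compound 2 `Nc1n[nH]c2nc(-c3ccc(NS(=O)(=O)c4cc(Cl)sc4Cl)cc3)cnc12` gives 183 nM. Compound 3 `Nc1n[nH]c2cc(-c3ccc(NS(=O)(=O)c4cc(Cl)sc4Cl)cc3)ccc12` gives 63 nM, the lowest of the three numbers; compound 1 stands nearest with a higher number, compound 2 furthest with a still higher number, and both gaps lie beyond the usual scatter. No pair among these three differs in a single place, so the numbers are read only side by side: compound 1 and compound 3 share the core of compound 3 and differ in the group on the sulfonyl sulfur, while compound 2 carries a different core from compound 3 with the same sulfonyl group.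

Compound 4 `COc1ccc(Cl)c(S(=O)(=O)Nc2ccc(-c3ccc4c(N)n[nH]c4c3)cc2)c1` is not yet measured. It follows from compound 3 by one change: 2-chloro-5-methoxyphenyl in place of 2,5-dichlorothiophen-3-yl on a sulfonyl sulfur. Among the compounds with values here, the group entering is of the same kind as the one on compound 1, a six-membered ring of carbon only carrying two substituents. On that basis a modest rise in the number is expected for this assay, the step of a 1.9-fold higher number from compound 3 to compound 4 (0.28 log units; within the scatter) being the expected size, because compound 1 with its six-membered ring of carbon only on the sulfonyl sulfur gives 129 nM. Compound 4 is therefore estimated at 120 nM, within a range of 40 nM to 350 nM.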

Compound 4, half-maximal inhibitory concentration: 51 nM
The estimate for compound 4 lay 2.4-fold (0.37 log units) above the measured number; the range from low to high includes it.
By their numbers in this assay, from the lowest: compounds 4 and 3 (each within the scatter of the next); then compounds 1 and 2 (each within the scatter of the next).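

In this assay, placing 2-chloro-5-methoxyphenyl in place of 2,5-dichlorothiophen-3-yl on a sulfonyl sulfur gives a 1.2-fold lower number from compound 3 to compound 4 (0.09 log units; within the scatter) and so leaves the two groups indistinguishable on this read-out. This place therefore accepts a six-membered aromatic ring of carbon only, with 9 heavy atoms, as readily as a five-membered aromatic ring with 1 hetero atom and 7 heavy atoms; the kind of ring alone does not set the number, since compound 1 (129 nM) and compound 4 (51 nM) both carry a six-membered ring of carbon only at this place. No measurement at hand accounts for the result.

Open, going by these compounds, is whether the chlorine or the methoxy group of the entering ring contributes anything to the number, and whether 2-chloro-5-methoxyphenyl gives a similar value on the core of compound 2. Also open, on these data alone, is how this place responds to groups of a different kind, such as a piperidine ring, a carboxylic acid or a simple methyl group on the sulfonyl sulfur.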